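The source may report more compounds than this note shows. Statements on the series, on what has been measured and on what is new or still open speak of the compounds shown alone.

Compounds measured in this study:

Compound 1, `CC(C)(O)C(CCC/C=C(\c1ccccc1)c1cccnc1)C(=O)O`, 42 nM
Compound 2, `O=C(O)C(CCC/C=C(\c1ccccc1)c1cccnc1)Sc1ccccc1`, 33 nM
Compound 3, `O=C(O)CCCC/C=C(\c1cccnc1)c1cccc([N+](=O)[O-])c1`, 73 nM

In an assay (Equus caballus) for inhibition of Thromboxane-A synthase (Homo sapiens), using microsomes (a higher number here means a weaker inhibitor, a lower number a stronger inhibitor), compound 1 gives 42 nM, the second highest of the three numbers; compound 2 sits nearest at 33 nM, and compound 3 furthest at 73 nM, both within the scatter of compound 1. Going by the values given here, the one step that can be measured, a 1.3-fold lower number from compound 1 to compound 2 (0.10 log units; within the scatter), shows that changing the branch on the carbon next to the carbonyl carbon made no real difference.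

Compound 4, `NC(=O)CCCC/C=C(\c1ccccc1)c1cccnc1`, has not been measured. It differs from compound 1 by carbamoylmethyl in place of 1-carboxy-2-hydroxy-2-methylpropyl on a saturated chain carbon, three bonds along the chain from a double-bonded chain carbon. Among the compounds with values here, no measured step tests the loss of the carboxylic acid, which all three measured compounds keep; the step from compound 1 to compound 2 bears on the branch only. Compound 1 and compound 3 show that an unbranched acid chain gives a number within the scatter of a branched one. Since nothing measured covers an amide in place of the acid, compound 4 is expected to be somewhat weaker, with a step of a 4.8-fold higher number from compound 1 to compound 4 (0.68 log units; beyond the scatter), an estimate of 200 nM in this assay, and a range of 50 nM to 900 nM.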

Compound 4, half-maximal inhibitory concentration: 400 nM
Compound 4: the middle estimate sits 2.0-fold (0.30 log units) below what was measured, and the stated range covers the measured number.
By their numbers in this assay, from the lowest: compounds 2, 1 and 3 (each within the scatter of the next, the first and the last beyond it); then compound 4.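

In this assay, going by these compounds alone, this is the first change to move the number beyond the scatter, a 9.5-fold higher number from compound 1 to compound 4 (0.98 log units; beyond the scatter). Carbamoylmethyl in place of 1-carboxy-2-hydroxy-2-methylpropyl removes the carboxylic acid that all the earlier compounds keep, so this position, on a saturated chain carbon, three bonds along the chain from a double-bonded chain carbon, now tolerates a change with a clear cost, yet the loss of the acid does not abolish inhibition, since compound 4 still gives a measurable number. No measured evidence on why the number moves by this much is available.

The step changes the acid and the branch together, so it cannot show how much of the difference belongs to each. An unbranched carboxylic acid on the core of compound 4, or a methyl ester or a tetrazole in its place, would separate the two.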